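The source may report more compounds than this note shows. Statements on the series, on what has been measured and on what is new or still open speak of the compounds shown alone.

Measured compounds and their values:
Compound 1 `Nc1cc(N)c2nc(-c3ccccc3)c(NCc3ccc(Cl)c(Cl)c3)nc2c1` gives 1740 nM
Compound 2 `COc1ccc(CNc2nc3cc(N)cc(N)c3nc2-c2ccccc2)cc1OC` gives 8320 nM
Compound 3 `Nc1cc(N)c2nc(-c3ccccc3)c(NCc3ccc(F)cc3)nc2c1` gives 3470 nM

All three share one core and differ only in the group carried on the saturated chain carbon bound to a nitrogen of that core. In a functional assay on PC-3 cells (Homo sapiens) for inhibition, read by sulforhodamine B assay, with a stated time of 48 h (on this read-out lower numbers stand for stronger inhibition of growth and higher numbers for weaker inhibition of growth), compound 3 stands second highest of the three numbers; its nearest neighbour is compound 1, and the gap a 2.0-fold higher number from compound 1 to compound 3 (0.30 log units; within the scatter) lies within the scatter, while compound 2 sits further away, with a 2.4-fold lower number from compound 2 to compound 3 (0.38 log units; beyond the scatter) beyond it.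

Compound 4 `COc1ccc(CNc2nc3cc(N)cc(N)c3nc2-c2ccccc2)cc1` is the next step: methoxy in place of fluoro on an aromatic carbon. For the measured compounds named here, two measured steps bear on this. The dimethoxy compound 2 was weaker than the dichloro compound 1, a 4.8-fold higher number from compound 1 to compound 2 (0.68 log units; beyond the scatter), and replacing the dimethoxy group by a single fluoro improved matters, a 2.4-fold lower number from compound 2 to compound 3 (0.38 log units; beyond the scatter). Both point the same way: methoxy groups on this ring have so far gone with higher numbers. Compound 4 carries only one methoxy, so the estimated shift in this assay is roughly a 1.7-fold higher number from compound 3 to compound 4 (0.24 log units; within the scatter), upward yet smaller than the full dimethoxy step.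

Compound 4 is therefore estimated at 6000 nM, with a likely range from 2500 nM to 14000 nM.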

Compound 4, concentration for 50% growth inhibition: 10200 nM
Compound 4: middle estimate off by 1.7-fold (0.23 log units), on the low side; the measured number falls inside the stated range.
By their numbers in this assay, from the lowest: compounds 1 and 3 (each within the scatter of the next); then compounds 2 and 4 (each within the scatter of the next).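

In this assay, a single group change is enough to weaken growth inhibition: with fluoro replaced by methoxy on this aromatic carbon, para to a large group, the step is a 2.9-fold higher number from compound 3 to compound 4 (0.47 log units; beyond the scatter) and so does not depend on a second methoxy being present. The second methoxy of compound 2 makes no difference that can be told apart, as a 1.2-fold higher number from compound 2 to compound 4 (0.09 log units; within the scatter) shows, so among these compounds the weaker result does not grow with the number of methoxy groups. Measured against the 3,4-dichlorophenyl group, the 4-methoxyphenyl group gives a 5.9-fold higher number from compound 1 to compound 4 (0.77 log units; beyond the scatter) and this is the widest gap among the four compounds.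

Nothing measured here explains why methoxy goes with the higher numbers at this position. The compounds shown also leave open how a hydroxyl, an amine or a plain methyl in the same place would compare with fluoro and methoxy, which would help separate the role of the oxygen from that of the added carbon.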